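The source may report more compounds than this note shows. Statements on the series, on what has been measured and on what is new or still open speak of the compounds shown alone.

Working notes on the series. Compound 2 `CCOc1cc([C@](O)(CCN(C)C)[C@@H](c2cc3cc(Br)ccc3nc2OC)c2ccnc(OC)c2OC)cc(OC)n1` gives 3.8 uL/min in an ADME assay on microsomes from liver (Homo sapiens) for metabolic stability; on this read-out lower numbers stand for slow clearance and higher numbers for fast clearance. Compound 1 `CCOc1cc([C@](O)(CCN(C)C)[C@H](c2cccc(C)c2)c2cc3cc(Br)ccc3nc2OC)cc(OC)n1` gives 4.4 uL/min, a step of a 1.2-fold lower number from compound 1 to compound 2 (0.06 log units; within the scatter). Among the measured compounds shown here, compound 3 `CCOc1cc([C@](O)(CCN(C)C)[C@@H](c2cc3cc(Br)ccc3nc2OC)c2ccnc(OC)c2OC)cc(OC(C)C)n1` gives 1.8 uL/min, the one step beyond the scatter: a 2.1-fold lower number from compound 2 to compound 3 (0.32 log units; beyond the scatter). Compound 2 therefore stands second highest of the three numbers, though its gap to compound 1 is within the scatter. Compound 4 `COc1nc2ccc(Br)cc2cc1[C@@H](c1ccnc(OC)c1OC)[C@@](O)(CCN(C)C)c1cc(SC)nc(SC)c1` is not yet measured; it differs from compound 2 by a group of 10 heavy atoms (7 carbon, 1 nitrogen, 2 sulfur; one six-membered aromatic ring with 1 hetero atom) in place of a group of 11 heavy atoms (8 carbon, 1 nitrogen, 2 oxygen; one six-membered aromatic ring with 1 hetero atom), on a saturated chain carbon bound to an oxygen on a saturated carbon and two saturated chain carbons. Neither measured step touches this site: the change toward compound 3 sits on an oxygen on an aromatic ring, and the change toward compound 1 lies elsewhere. For the measured compounds named here, no measured step covers a swap of this kind, so the expectation rests on the spread of the series alone. Compound 4 is expected at 5 uL/min, with a range from 2.5 uL/min to 10 uL/min. This expected step is a 1.3-fold higher number from compound 2 to compound 4 (0.12 log units; within the scatter), close to the scatter.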

Compound 4, intrinsic clearance in a liver preparation (reported as CLH), per the amount of preparation that the assay uses: 8.8 uL/min
Compound 4: the middle estimate sits 1.8-fold (0.25 log units) below what was measured; the measured number falls inside the stated range.
By their numbers in this assay, from the lowest: compound 3; then compounds 2, 1 and 4 (each within the scatter of the next, the first and the last beyond it).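

At this place, on a saturated chain carbon bound to an oxygen on a saturated carbon and two saturated chain carbons, the change of group moves the read-out in this assay by a 2.3-fold higher number from compound 2 to compound 4 (0.36 log units; beyond the scatter). Compound 4 is the only compound shown that carries sulfur, and this is the first step at this place that can be read. Nothing available bears on what lies behind this step. From the compounds shown here alone, both sulfur atoms enter together, so the share of each stays open. Going by these compounds, how an amine on this aromatic ring would read out also stays open.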